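The source may hold more compounds than are shown below. What is called first, only, known or untested is meant among the compounds shown, and "the series" means these compounds.

Measured in an assay on isolated protein for inhibition of ATP-citrate synthase (Rattus norvegicus); on this read-out higher numbers stand for weaker inhibition and lower numbers for stronger inhibition:

compound 1 `O=C(O)CC(O)(CSCCCC/C=C/c1ccc(Cl)cc1Cl)C(=O)O` gives 7400 nM
compound 2 `O=C(O)CC(O)(CSCCCCCc1ccc(-c2ccccc2)cc1)C(=O)O` gives 226000 nM
compound 3 `O=C(O)CC(O)(CSCCCCCCc1ccc(-c2ccccc2)cc1)C(=O)O` gives 38000 nM

Compound 3 stands second highest of the three numbers in this assay. Compound 1 sits lower, beyond the scatter; compound 2 sits higher, also beyond the scatter. Neither pair differs in one place only, so their values are taken as they stand.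

Compound 4 `NS(=O)(=O)c1ccc(CCCCCCSCC(O)(CC(=O)O)C(=O)O)cc1` differs from compound 3 by sulfamoyl in place of phenyl on an aromatic carbon. No measured step covers a change of this kind in the series, so the expectation rests on compound 3 alone. The step from compound 3 to compound 4 is expected to be a 1.6-fold higher number from compound 3 to compound 4 (0.20 log units; within the scatter), toward weaker inhibition, modest and uncertain. Compound 4 is estimated at 60000 nM in this assay, with a range from 15000 nM to 250000 nM.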

Compound 4, inhibition constant: 500000 nM
For compound 4 the middle estimate is 8.3-fold (0.92 log units) below the measured one; measured number outside the range, above it.
By their numbers in this assay, from the lowest: compound 1; then compound 3; then compound 2; then compound 4.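

In this assay, sulfamoyl in place of phenyl on the aromatic carbon para to a large group gives a 13-fold higher number from compound 3 to compound 4 (1.12 log units; beyond the scatter), a large move toward weaker inhibition. Within the data shown here, this is the first step that isolates a change at this position, and it shows that the position is sensitive to the group it carries. No measurement at hand explains the size of this step.

A single replacement does not separate the loss of the phenyl from the arrival of sulfamoyl. From the compounds shown here alone, how an amine or a carboxylic acid on the same aromatic carbon would read remains open.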